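The source may hold more compounds than are shown below. What is called first, only, known or untested is meant among the compounds shown, and "the series" means these compounds.

Measured compounds and values:
compound 1 `COc1ccc(CNc2nc([Se]C)nc3ccccc23)cc1` gives > 100000 nM in a functional assay on HT-29 cells (Homo sapiens) for cytotoxicity, read by MTT assay, with a stated time of 72 h (on this read-out lower numbers stand for higher toxicity in this test and higher numbers for lower toxicity in this test), a limit of the assay.
compound 2 `CSc1nc(NCCCCCO)c2cccnc2n1` gives > 100000 nM in this assay, a limit of the assay.
compound 3 `COc1ccc(CNc2nc(SC)nc3ccccc23)cc1` gives > 100000 nM in this assay, a limit of the assay.

Among the compounds with values here, compound 1 stands only at a limit, and the two further values shown are limits as well; all three sit at the same limit (the limit of > 100000 nM in this assay, at which 3 of the 3 values shown sit), so no compound in this set has a number. Within the data shown here, the single step between compounds that differ in one place is a step that the two limits leave unreadable from compound 1 to compound 3, and both limits leave its size unreadable. Compound 2 has no single-point relation to compound 1; its value shows only the same limit.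

Compound 4 `CSc1ccc(CNc2nc([Se]C)nc3ccccc23)cc1` differs from compound 1 by methylsulfanyl in place of methoxy on an aromatic carbon. Among the measured compounds shown here, no measured step touches the methoxy of compound 1, and the one step that was measured cannot be read. Nothing in the set therefore points to a step in this assay in either direction, and the expectation is that compound 4 again reaches no number. The estimate for compound 4 is 150000 nM, with a range from 40000 nM to 600000 nM. This corresponds to an expected step that the limit leaves unreadable from compound 1 to compound 4, which is most likely to be reported only as a limit.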

Compound 4, concentration lethal to 50% of the cells: > 100000 nM
Compound 4: only a limit was reported; the forecaster's own chance of this, stated with the estimate: 80%; the middle value is on the limit's open side.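

In this assay compound 4 gives > 100000 nM, a limit of the assay and not a number, so no new step can be read between compound 1 and compound 4, which carry methoxy and methylsulfanyl. The compounds shown leave open the size of any step among them, with every value at one limit: the limit of > 100000 nM in this assay, at which 4 of the 4 values shown sit.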